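The compounds below may be only part of what the source reports. "The series", "measured", "known", "first", "only" and "open" are said of these compounds alone.

Compound 1, `NS(=O)(=O)c1ccccc1NC(=O)Nc1ccc(Cl)c(C(F)(F)F)c1`, is one of two measured ureas built on the shared core, and the other is compound 2, `O=C(Nc1ccc(Cl)c(C(F)(F)F)c1)Nc1cccc2[nH]ccc12`. In an in vitro functional assay on cells for antagonist activity at transient receptor potential cation channel subfamily V member 1 (Homo sapiens), read by reporter gene assay and calcium flux (on this read-out lower numbers stand for stronger inhibition and higher numbers for weaker inhibition), compound 2 gives 33 nM. For compound 1 this assay reports only a limit, > 1000 nM, so no number for its potency is known and it stands at the limit of > 1000 nM in this assay, at which 1 of the 2 values shown sits. The unmeasured compound 3, `O=C(Nc1ccc(Cl)c(C(F)(F)F)c1)Nc1ccccc1CO`, keeps the same core and differs from compound 1 by hydroxymethyl in place of sulfamoyl on an aromatic carbon. Because compound 1 sits at > 1000 nM, any gain would start from a limit rather than from a number; a step from compound 1 to compound 3 of an at least 2.0-fold lower number from compound 1 to compound 3 (0.30 log units; that floor lies within the scatter) toward stronger inhibition is expected, though with wide uncertainty. Compound 3 is therefore estimated at 500 nM in this assay, with a likely range from 100 nM to 3000 nM.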

Compound 3, half-maximal inhibitory concentration: 330 nM
For compound 3 the middle estimate is 1.5-fold (0.18 log units) above the measured one, and the stated range covers the measured number.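

Hydroxymethyl in place of sulfamoyl, on an aromatic carbon ortho to a large group, gives the first step that can be read at this position in this assay: the change brings an at least 3.0-fold lower number from compound 1 to compound 3 (0.48 log units; beyond the scatter) and turns a limit into a measured value. It shows that the sulfamoyl group is not needed at this place for measurable inhibition on the shared core. Going by these compounds, the full size of the step stays unknown because compound 1 stands at a limit and not at a number: the limit of > 1000 nM in this assay, at which 1 of the 3 values shown sits.

The compounds shown leave open whether the hydroxyl of the hydroxymethyl group matters, since a plain methyl group does not appear among them. They also leave open how an aminomethyl group, a carboxylic acid or a longer chain such as hydroxyethyl would read at this place.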